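The source may hold more compounds than are shown below. What is called first, only, known or untested is meant among the compounds shown, and "the series" means these compounds.

Measured compounds and their values in a functional assay on HepG2 cells (Homo sapiens) for antiproliferative activity, read by MTT assay, with a stated time of 72 h; on this read-out lower numbers stand for stronger inhibition and higher numbers for weaker inhibition:

- compound 1, `FC(F)(F)c1ccc(COc2cccc(Nc3ncnc4cc5c(cc34)OCCOCCO5)c2)cc1`: > 100000 nM
- compound 2, `O=[N+]([O-])c1ccc(COc2ccccc2Nc2ncnc3cc4c(cc23)OCCOCCOCCO4)cc1`: 60800 nM
- compound 3, `FC(F)(F)c1ccc(COc2ccc(Nc3ncnc4cc5c(cc34)OCCOCCO5)cc2)cc1`: > 100000 nM

Compound 1 gives > 100000 nM, which is a limit of the assay, not a number. For compound 3 the value > 100000 nM is likewise a limit. Among the compounds with values here, compound 2 therefore stands alone: it is the only compound of the three with a measured number in this assay, giving 60800 nM, while the other two sit at the limit of > 100000 nM in this assay, at which 2 of the 3 values shown sit. Its number is itself high, so the inhibition it shows is weak.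

The next compound, compound 4, `FC(F)(F)c1ccc(COc2ccccc2Nc2ncnc3cc4c(cc23)OCCOCCOCCO4)cc1`, differs from compound 2 in one place: trifluoromethyl in place of nitro on an aromatic carbon. Within the data shown here, no measured pair shows this change on its own, so its effect here is not known. Compound 1 and compound 3, which carry the trifluoromethyl group, both sit at the limit, but they differ from compound 4 in other places as well, so they cannot be read as a step.

Given how weakly compound 2 acts, compound 4 is expected to change little or drift toward weaker inhibition, a step of a 1.5-fold higher number from compound 2 to compound 4 (0.17 log units; within the scatter) that is at most just beyond the scatter. The estimate for compound 4 in this assay is 90000 nM, with a range from 30000 nM to 300000 nM, and a real chance that only a limit is reported.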

Compound 4, half-maximal inhibitory concentration: > 100000 nM
Compound 4: only a limit was reported (the forecaster's own chance of this, stated with the estimate: 50%); middle value at least 1.1-fold (0.04 log units) from the limit.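

In this assay compound 4 gives > 100000 nM, which is a limit of the assay and not a number. Within the data shown here, this is the first direct reading of trifluoromethyl in place of nitro at this place, para to a large group, and the change gives an at least 1.6-fold higher number from compound 2 to compound 4 (0.21 log units; that floor lies within the scatter), so it shows no real loss of activity, though it does not rule one out either. Among these compounds, the true size of the step cannot be read because compound 4 joins the other compounds that give no number, so only its floor is known and nitro remains the only group at this place with a measured value: the limit of > 100000 nM in this assay, at which 3 of the 4 values shown sit.

The compounds shown leave open whether a different group at this place, such as an amine or a carboxylic acid, would bring the number down into a clearly stronger range, or whether the whole series stays weak on this read-out. They also leave open whether nitro would give a measured number on the core of compound 1 or the core of compound 3, where only limits are shown so far.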